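Compound 1 to compound 3: methoxymethoxy in place of hydrogen

A few compounds are considered here, and "the series" means these few. Any claim that something is new, unique, unknown or untested is made for them only; others in the source may bear on it.

Measured compounds in an ADME assay on PA-1 cells (Homo sapiens) for cytotoxicity, read by MTT assay, with a stated time of 72 h; a lower number here means a stronger inhibitor, a higher number a weaker inhibitor (values as read):
- compound 1 `COc1ccc(C2=C(c3cc(OC)c(OC)c(OC)c3)C(=O)CC2O[SiH2]C(C)(C)C)cc1` gives > 100 ug/mL (a limit, not a number)
- compound 2 `COc1ccc(C2=C(c3cc(OC)c(OC)c(OC)c3)C(=O)CC2O)cc1` gives 3.38 ug/mL (a number)

Compound 1 sits at the limit of > 100 ug/mL in this assay, at which 1 of the 2 values shown sits, and has no number of its own. The move to compound 3 `COCOc1cc(C2=C(c3cc(OC)c(OC)c(OC)c3)C(=O)CC2O[SiH2]C(C)(C)C)ccc1OC` is methoxymethoxy in place of hydrogen on an aromatic carbon and leaves the rest of compound 1 unchanged. Among the compounds with values here, the only measured step is an at least 29-fold lower number from compound 1 to compound 2 (1.47 log units; beyond the scatter) and it is large, but it takes place on an oxygen on a saturated carbon and not on an aromatic carbon. Within the data shown here, no measured step gives a direct size for methoxymethoxy in place of hydrogen. Compound 3 keeps the group whose replacement by hydrogen gave an at least 29-fold lower number from compound 1 to compound 2 (1.47 log units; beyond the scatter) and so no step beyond the scatter is expected in this assay, with a further reading at the limit being likely. The estimated step is a number no higher from compound 1 to compound 3 (the limit leaves the size open) and it is uncertain in size and direction. For compound 3 the estimate is 100 ug/mL with an expected range (35 ug/mL to 200 ug/mL).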

Compound 3, half-maximal inhibitory concentration: 13.5 ug/mL
Beside the measured number, compound 3's estimate is 7.4-fold (0.87 log units) above it, and the stated range ends above it.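

The change from 4-methoxyphenyl to 4-methoxy-3-(methoxymethoxy)phenyl registers in this assay and gives an at least 7.4-fold lower number from compound 1 to compound 3 (0.86 log units; beyond the scatter), so this aromatic carbon, ortho to a methoxy group, is a place where the read-out can move. The earlier measured step, an at least 29-fold lower number from compound 1 to compound 2 (1.47 log units; beyond the scatter), lay on an oxygen on a saturated carbon, whereas compound 3 keeps the silicon-bearing group and still gives a number, so that group alone does not hold the series at the limit. Compound 1 gives > 100 ug/mL, a limit and not a number, so the true size of the new step stays open: the limit of > 100 ug/mL in this assay, at which 1 of the 3 values shown sits.

Whether the gain belongs to methoxymethoxy itself or to any substituent on this aromatic carbon remains open, since only this one group is shown there, and an amine, an ethoxy group or a longer alkoxy chain in the same place would help to separate the two. Also open, going by these compounds, is how methoxymethoxy on this carbon reads when the oxygen on the saturated carbon carries hydrogen, as it does in compound 2.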